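Ethyl for iodo on a urea-linked phenyl ring

This account rests on a few compounds, and the source may have more. Where it says the series, first, only, none or still open, it means among the compounds named here.

Measured so far:
- compound 1, `O=C(Nc1ccc(I)cc1)Nn1c(-c2ccccc2)nc2ccccc2c1=O`, gives 60% in a functional assay on the whole organism (strain albino) with Mus musculus as the target, at a dose of 100 mg/kg by the intraperitoneal route; on this read-out lower numbers stand for less inhibition and higher numbers for more inhibition at the one dose given (going by the name of the read-out)
- compound 2, `CCc1nc2ccccc2c(=O)n1NC(=O)Nc1ccc([N+](=O)[O-])cc1`, gives 41% in this assay

Of the two compounds with numbers, compound 1 stands highest in this assay; its nearest neighbour, compound 2, lies lower by a margin that is beyond the scatter. Compound 2 differs from compound 1 in more than one place, so its gap to compound 1 cannot be traced to a single change and says only what the two values show.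

The step to be followed leads from compound 1 to compound 3, whose structure is `CCc1ccc(NC(=O)Nn2c(-c3ccccc3)nc3ccccc3c2=O)cc1`. The change is small: ethyl in place of iodo on an aromatic carbon The group leaves and enters on an aromatic carbon of a six-membered aromatic ring of carbon only, para to a large group; the rest of compound 1 is kept.

Within the data shown here, no measured pair shows this exact change, so the direction is uncertain. A small step is expected, most likely downward or within the scatter, so that compound 3 is estimated at 50% in this assay, with a range from 30% to 70%, corresponding to an expected step of a number 10 percentage points lower from compound 1 to compound 3 (within the scatter).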

Compound 3, a percentage reported as inhibition, in the whole organism at one dose (the size of the read-out at that dose, not a potency): 61%
Compound 3: the middle estimate sits 11 percentage points below what was measured; the measured number falls inside the stated range.
By their numbers in this assay, from the lowest: compound 2; then compounds 1 and 3 (each within the scatter of the next).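

In this assay, putting ethyl in place of iodo on an aromatic carbon, para to a large group, gives a number 1 percentage points higher from compound 1 to compound 3 (within the scatter). Among these compounds, this is the first comparison here that isolates a single change, and it shows that at this position a lone iodine atom and a two-carbon chain, neither with any hydrogen-bond donors or acceptors, cannot be told apart at the one dose given, while the rest of the molecule stays the same. No supporting measurement is available to explain this result.

Iodo and ethyl both count no hydrogen-bond donors or acceptors, so the compounds shown leave open whether the same position would accept an amine or a carboxylic acid, or a longer chain such as butyl, with a similar read-out. On these data alone, the read-out also comes from a single dose, and whether compound 1 and compound 3 would still match at other doses remains open.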